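The source may hold more compounds than are shown below. What is called first, only, known or untested is meant among the compounds shown, and "the series" means these compounds.

Measured so far:
compound 1 `Oc1ccc(O)c(/C=N/c2ccc(OCc3ccccc3)cc2)c1` — 21300 nM
compound 2 `Oc1ccc(/C=N/c2ccc(OCc3ccccc3)cc2)c(O)c1` — > 200000 nM, a limit
compound 3 `Cc1ccc(/C=N/c2ccc(OCc3ccccc3)cc2)c(O)c1` — > 200000 nM, a limit

For the measured compounds named here, in a functional assay, with a stated time of 30 min (a lower number here means a stronger inhibitor, a higher number a weaker inhibitor), compound 1 gives 21300 nM, the only number among the three measured compounds. Compound 2 sits at the limit > 200000 nM. Compound 3 sits at the limit > 200000 nM. Both of these are the limit of > 200000 nM in this assay, at which 2 of the 3 values shown sit.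

Both measured steps leave the 2,5-dihydroxyphenyl of compound 1: an at least 9.3-fold higher number from compound 1 to compound 2 (0.97 log units; beyond the scatter) with 2,4-dihydroxyphenyl, and an at least 9.3-fold higher number from compound 1 to compound 3 (0.97 log units; beyond the scatter) with 2-hydroxy-4-methylphenyl. Between the two limits, a step that the two limits leave unreadable from compound 2 to compound 3.

Compound 4 `O=[N+]([O-])c1ccc(O)c(/C=N/c2ccc(OCc3ccccc3)cc2)c1` differs from compound 1 by nitro in place of hydroxy on an aromatic carbon. The steps from compound 1 that bear on it are the two that alter the same ring, and each gave an at least modest loss to a limit. A loss of that order is therefore expected here too, a 5.6-fold higher number from compound 1 to compound 4 (0.75 log units; beyond the scatter), with a fair chance that compound 4 is again reported only as a limit. Compound 4 is estimated at 120000 nM, within 25000 nM to 250000 nM.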

Compound 4, half-maximal inhibitory concentration: > 200000 nM
Compound 4: no number, only a limit (the forecaster's own chance of this, stated with the estimate: 50%); middle value at least 1.6-fold (0.22 log units) from the limit.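

At this place on the ring, para to a hydroxy group, nitro in place of hydroxy gives an at least 9.3-fold higher number from compound 1 to compound 4 (0.97 log units; beyond the scatter) in this assay. Compounds 2 and 3 carry no group at this place, while compound 4 does, so having a group here is not enough to keep a measurable value, and among the four compounds only the hydroxy of compound 1 gives a number. The value of compound 4 is a limit, the same one reached by compounds 2 and 3: the limit of > 200000 nM in this assay, at which 3 of the 4 values shown sit.

The true size of all these losses cannot be read, and neither can any order among compounds 2, 3 and 4. As far as these compounds go, whether an amine, a methoxy group or a carboxylic acid at this place would give a measurable value remains open.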